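A methyl in place of fluorine on the ring-bound phenyl

The source may report more compounds than this note shows. Statements on the series, on what has been measured and on what is new or still open speak of the compounds shown alone.

Three compounds have been tested in a functional assay on the whole organism (strain Swiss) with Mus musculus as the target, in the maximal electroshock model, with a stated time of 0.5 h, at a dose of 300 mg/kg by the intraperitoneal route; a lower number here means a weaker effect, a higher number a stronger effect of the compound at the dose given:
compound 1, `CCC(C(=O)N1CCN(c2ccccc2Cl)CC1)N1C(=O)CCC1=O`, gives 25%
compound 2, `CCC(C(=O)N1CCN(c2cccc(F)c2)CC1)N1C(=O)CCC1=O`, gives 100%
compound 3, `CCC(C(=O)N1CCN(c2ccccc2F)CC1)N1C(=O)CCC1=O`, gives 100%

Compound 3 stands level with compound 2 at the digits shown, and together the two are the highest of the three numbers; the only lower value is that of compound 1, with a number 75 percentage points higher from compound 1 to compound 3 (beyond the scatter). Compound 4, `CCC(C(=O)N1CCN(c2cccc(C)c2)CC1)N1C(=O)CCC1=O`, has not yet been measured; it differs from compound 3 by 3-methylphenyl in place of 2-fluorophenyl on an amine nitrogen in a ring. For the measured compounds named here, two measured steps bear on changes to this phenyl group: a number 75 percentage points higher from compound 1 to compound 2 (beyond the scatter) and a number 75 percentage points higher from compound 1 to compound 3 (beyond the scatter) were both large, while no change at the digits printed from compound 2 to compound 3 (within the scatter). So moving the fluorine around the ring cost nothing, and the chloro-bearing compound 1 alone is weak. Going by the values given here, no measured step exchanges a fluorine for a methyl, so the effect of that swap is unknown. The expectation for compound 4 is a small downward step, a number 15 percentage points lower from compound 3 to compound 4 (beyond the scatter), within or only slightly beyond the scatter. Compound 4 is therefore estimated at 85%, between 50% and 100%.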

Compound 4, a percentage reported as activity, at one dose (the size of the read-out at that dose, not a potency): 100%
The estimate for compound 4 lay 15 percentage points below the measured number, within the range that was stated.
By their numbers in this assay, from the lowest: compound 1; then compounds 2, 3 and 4 (each within the scatter of the next).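

With no change at the digits printed from compound 2 to compound 4 (within the scatter), a methyl group on the phenyl ring serves as well as a fluoro group in this assay, so a high value does not depend on the ring carrying fluorine. For the compounds shown here, the change of both the group and its place gives no change at the digits printed from compound 3 to compound 4 (within the scatter), while a number 75 percentage points higher from compound 1 to compound 4 (beyond the scatter) leaves the 2-chlorophenyl compound as the only low value among the four. Nothing available here explains this pattern.

A 3-chlorophenyl group would help show whether the low value of compound 1 goes with the chlorine itself or with its place on the ring, and a methoxy group or an amine on the phenyl would test how far the tolerance extends. Compounds 2, 3 and 4 print the same value at this one dose, which leaves any difference in potency among them open.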